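This account rests on a few compounds, and the source may have more. Where it says the series, first, only, none or still open, it means among the compounds named here.

Compound 1 `COc1ccc(NC(=O)Nc2cc(C)nc3ccccc23)cc1`: 19800 nM in a physicochemical assay for solubility, at pH 7.4; on this read-out lower numbers stand for lower solubility and higher numbers for higher solubility
Compound 2 `Cc1cc(NC(=O)Nc2ccc(C(=O)O)cc2)c2ccccc2n1`: 9300 nM
Compound 3 `CC(=O)c1ccc(NC(=O)Nc2cc(C)nc3ccccc23)cc1`: 3800 nM

Compound 3 stands lowest of the three in this assay. The nearer of its two steps is a 2.4-fold lower number from compound 2 to compound 3 (0.39 log units; beyond the scatter); the wider one is a 5.2-fold lower number from compound 1 to compound 3 (0.72 log units; beyond the scatter). Both changes sit on the same aromatic carbon of the shared core and both are modest in size.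

Compound 4 `Cc1cc(NC(=O)Nc2ccc(Cl)cc2)c2ccccc2n1` has not yet been measured. It differs from compound 3 in one place: chloro in place of acetyl on an aromatic carbon. Among the measured compounds shown here, no measured step swaps acetyl for chloro, so no step bears on this change directly. What the measured steps on that carbon do show, through a 5.2-fold lower number from compound 1 to compound 3 (0.72 log units; beyond the scatter) and a 2.4-fold lower number from compound 2 to compound 3 (0.39 log units; beyond the scatter), is that swapping the group there moves the number by modest amounts, with acetyl giving the lowest value. With nothing measured for chloro, the direction is uncertain, and the expected step is a small one downward, a 1.5-fold lower number from compound 3 to compound 4 (0.18 log units; within the scatter). Compound 4 is estimated at 2500 nM, within 800 nM to 8000 nM.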

Compound 4, solubility: 1400 nM
For compound 4 the middle estimate is 1.8-fold (0.25 log units) above the measured one, within the range that was stated.
By their numbers in this assay, from the lowest: compound 4; then compound 3; then compound 2; then compound 1.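

In this assay, putting chloro in place of acetyl gives a 2.7-fold lower number from compound 3 to compound 4 (0.43 log units; beyond the scatter), so acetyl no longer marks the low end at this aromatic carbon and compound 4 now stands lowest of the four. The spread at this one position also widens: chloro in place of carboxy gives a 6.6-fold lower number from compound 2 to compound 4 (0.82 log units; beyond the scatter), and chloro in place of methoxy gives a 14-fold lower number from compound 1 to compound 4 (1.15 log units; beyond the scatter), the only large step among those shown. No accompanying measurement offers an explanation for these steps.

On these data alone, whether bromo or fluoro on this carbon would give a number close to that of chloro remains open. So does where an amine or a plain methyl would fall in this order, and whether chloro would give similar steps on a different core.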